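The source may hold more compounds than are shown below. What is called first, only, known or untested is meant among the compounds shown, and "the series" means these compounds.

Measured in a functional assay on DU-145 cells (Homo sapiens) for inhibition, read by trypan blue exclusion, with a stated time of 96 h; on this read-out lower numbers stand for stronger inhibition of growth and higher numbers for weaker inhibition of growth:
- compound 1 `COc1cc(/C=C(/Sc2ccc(Br)cc2)C(=O)c2ccc(Br)cc2)ccc1F`: 10000 nM
- compound 2 `O=C(/C(=C\c1c[nH]c2ccccc12)Sc1ccc(Br)cc1)c1ccc(Br)cc1`: 1000 nM

Compound 2 holds the lower of the two numbers, and so far it stands as the stronger inhibitor of growth in this assay. The next compound is compound 3 `Nc1c(Br)cc(Br)cc1/C=C(/Sc1ccc(Br)cc1)C(=O)c1ccc(Br)cc1`, which differs from compound 2 by one group: 2-amino-3,5-dibromophenyl in place of 1H-indol-3-yl on a double-bonded chain carbon bound to a double-bonded chain carbon. This puts 2-amino-3,5-dibromophenyl in place of 1H-indol-3-yl on a double-bonded chain carbon bound to a double-bonded chain carbon.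

Among the compounds with values here, only one measured step bears on this place: a 10-fold lower number from compound 1 to compound 2 (1.00 log units; beyond the scatter). There, 1H-indol-3-yl replaced 4-fluoro-3-methoxyphenyl. Compound 3 gives up the 1H-indol-3-yl again for a different substituted phenyl, and no measurement shows what its amino or bromine substituents do in this series. The one substituted phenyl measured here, in compound 1, gave 10000 nM, so part of that step is expected to be lost, though not necessarily all of it. The expected change, with wide uncertainty, is a 2.5-fold higher number from compound 2 to compound 3 (0.40 log units; beyond the scatter). For compound 3 the estimated value is 2500 nM, with an expected range of 400 nM to 12000 nM.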

Compound 3, concentration for 50% growth inhibition: > 100000 nM
Compound 3: no number, only a limit (the forecaster's own chance of this, stated with the estimate: 10%); middle value at least 40-fold (1.60 log units) from the limit.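

Compound 3 is recorded in this assay only as a limit, not as a number: the limit of > 100000 nM in this assay, at which 1 of the 3 values shown sits.

Within the data shown here, the position is much less permissive than the earlier compounds could show: 2-amino-3,5-dibromophenyl in place of 1H-indol-3-yl gives an at least 100-fold higher number from compound 2 to compound 3 (2.00 log units; beyond the scatter), and the same group in place of 4-fluoro-3-methoxyphenyl gives an at least 10-fold higher number from compound 1 to compound 3 (1.00 log units; beyond the scatter). The earlier step separated 1H-indol-3-yl from one substituted phenyl, whereas these steps also separate two substituted phenyl groups from each other, so at this position the outcome depends on what the phenyl carries and not just on phenyl against 1H-indol-3-yl. From the compounds shown here alone, both new steps are bounds, so their full size stays unknown.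

The compounds shown do not separate the amine from the two bromines within 2-amino-3,5-dibromophenyl, so it remains open which of them, or whether only the combination, goes with the loss of growth inhibition. A 2-aminophenyl group without the bromines and a 3,5-dibromophenyl group without the amine would divide that question, while an unsubstituted phenyl group would give the series a reference point for both.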